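A few compounds are considered here, and "the series" means these few. Any claim that something is new, unique, unknown or untested is made for them only; others in the source may bear on it.

In an ADME assay on HepG2 2.2.15 cells (Homo sapiens) for cytotoxicity (a higher number here means that more compound is tolerated, a lower number that less compound is tolerated), three compounds on one shared core have been measured. Compound 1 `O=c1c(CCO)c(-c2ccccc2Cl)c2cc(Cl)ccc2n1-c1ccccc1` gives 26000 nM. Compound 2 `O=CCc1c(-c2ccccc2Cl)c2cc(Cl)ccc2[nH]c1=O` gives 120000 nM. For compound 3 `CC12CCC(C(=O)OCCc3c(-c4ccccc4Cl)c4cc(Cl)ccc4[nH]c3=O)(OC1=O)C2(C)C` the assay reports only a limit, > 1800000 nM, and no number. Compound 3 therefore stands at the edge of what this assay can report, as seen in the limit of > 1800000 nM in this assay, at which 1 of the 3 values shown sits. No step between measured compounds that differ in one place exists among these three, so no measured step can guide the next one.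

Compound 4 `O=C(/C=C/c1cccnc1)OCCc1c(-c2ccccc2Cl)c2cc(Cl)ccc2[nH]c1=O` has not yet been measured in this assay. It differs from compound 3 in one place: a group of 8 heavy atoms (7 carbon, 1 nitrogen; one six-membered aromatic ring with 1 hetero atom) in place of a group of 11 heavy atoms (9 carbon, 2 oxygen; one five-membered non-aromatic ring of carbon only, one five-membered non-aromatic ring with 1 hetero atom), on a carbonyl carbon. Because compound 3 sits only at a limit, > 1800000 nM, the size of the step to compound 4 is open, and a step toward less tolerated compound, beyond the scatter, is expected rather than none. The step from compound 3 to compound 4 is estimated as an at least 6.0-fold lower number from compound 3 to compound 4 (0.77 log units; beyond the scatter). Compound 4 is expected to give about 300000 nM in this assay, with a likely range from 60000 nM to 1800000 nM.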

Compound 4, half-maximal cytotoxic concentration: 39000 nM
The estimate for compound 4 lay 7.7-fold (0.89 log units) above the measured number; the whole stated range lies above it.
By their numbers in this assay, from the lowest: compounds 1 and 4 (each within the scatter of the next); then compound 2. At a limit, above all of these: compound 3.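

In this assay, putting 2-(pyridin-3-yl)ethenyl on a carbonyl carbon in place of the group of 11 heavy atoms gives an at least 46-fold lower number from compound 3 to compound 4 (1.66 log units; beyond the scatter), the only step measured among these compounds, and a large one. Among the compounds shown here, this shows that the group at this place can by itself move the number far beyond the scatter, which the earlier compounds could not show, as no two of them differed in one place. The full size of the step cannot be read, because compound 3 is held only at a limit: the limit of > 1800000 nM in this assay, at which 1 of the 4 values shown sits.

As far as these compounds go, it remains open whether the six-membered aromatic ring or the double bond in the entering group goes with the lower number. From the compounds shown here alone, it is also open how a phenyl ring, a saturated carbon chain or an amine would read at this place.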